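A few compounds are considered here, and "the series" means these few. Any claim that something is new, unique, unknown or untested is made for them only; others in the source may bear on it.

Compound 1 `CS(=O)(=O)c1ccc(-n2ccc3cnc(Nc4cnn(CCCCCC(=O)NO)c4)nc32)cc1` and compound 2 `O=C(CCCCCCn1cc(Nc2ncc3ccn(Cc4ccccc4)c3n2)cn1)NO` share one core and the same hydroxamic acid chain; they differ in what hangs on the core. In an assay on isolated protein for inhibition of protein deacetylase HDAC6 (Homo sapiens), with a stated time of 60 min (on this read-out higher numbers stand for weaker inhibition and lower numbers for stronger inhibition), compound 1 gives 10.8 nM. In this assay compound 2 gives 12.5 nM, which is the higher of the two numbers, but the two values lie within the usual scatter of each other, so no order between them can be read.

Compound 3 `O=C(CCCCCCn1cc(Nc2ncc3ccn(CC4CC4)c3n2)cn1)NO` is compound 2 with one alteration: cyclopropyl in place of phenyl on a saturated chain carbon bound to an aromatic nitrogen. Everything else, including the chain carrying the hydroxamic acid, stays as it is. Among the measured compounds shown here, no measured pair shows what this particular change does, so the expectation rests only on the two values at hand and on the fact that the change sits away from the hydroxamic acid.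

For compound 3 in this assay the expected step from compound 2 is small, a 1.3-fold higher number from compound 2 to compound 3 (0.11 log units; within the scatter), and is not expected to go beyond the scatter in either direction. Compound 3 is therefore estimated at 16 nM, with a likely range from 6 nM to 45 nM.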

Compound 3, half-maximal inhibitory concentration: 16 nM
The estimate for compound 3 equals the measured number at the digits printed, and the stated range covers the measured number.
By their numbers in this assay, from the lowest: compounds 1, 2 and 3 (each within the scatter of the next).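

Among the compounds shown here, replacing benzyl with cyclopropylmethyl on the shared core is the first single-place change available here, and in this assay it gives a step of a 1.3-fold higher number from compound 2 to compound 3 (0.11 log units; within the scatter), so compound 2 and compound 3 cannot be told apart on this read-out. The group on the saturated chain carbon bound to an aromatic nitrogen thus goes from a six-membered aromatic ring of 6 heavy atoms to a three-membered non-aromatic ring of 3 heavy atoms, and the result stays within the usual scatter, which shows that for this pair an aromatic ring at this place is not needed to keep the read-out in the same range. Nothing available explains why these two groups give such similar numbers.

On these data alone, it remains open whether this place tolerates groups of another kind, such as an amine, a carboxylic acid or a longer carbon chain ending in a phenyl ring, or whether one of these would produce a step beyond the scatter. As far as these compounds go, it is also open whether compound 2 and compound 3 would remain this close on any other protein deacetylase.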